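Neopentyl to benzyl on the imidazole carbon of compound 2

A few compounds are considered here, and "the series" means these few. Any claim that something is new, unique, unknown or untested is made for them only; others in the source may bear on it.

For the measured compounds named here, compound 2 `CC(C)(C)Cc1cnc(CCc2ccc(-c3ccccc3C(=O)O)cc2)[nH]1` gives 106 nM in an in vitro functional assay on cells for agonist activity at Bombesin receptor subtype-3 (Homo sapiens), read by luminescence and calcium flux (a higher number here means that more compound is needed for the effect, a lower number that less compound is needed), the lowest of the three numbers so far. Going by the values given here, compound 3 `CCCCc1cnc(C(CCCO)Cc2ccc(-c3ccccc3C(=O)O)cc2)[nH]1` gives 1900 nM and compound 1 `CCCCc1cnc(C(CCCC)Cc2ccc(-c3ccccc3C(=O)O)cc2)[nH]1` gives 2660 nM; the only single-point step among the measured compounds, a 1.4-fold lower number from compound 1 to compound 3 (0.15 log units; within the scatter), is within the scatter. Among the compounds with values here, compound 2 differs from compounds 1 and 3 in more than one place, so no step links it to either.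

Compound 4 `O=C(O)c1ccccc1-c1ccc(CCc2ncc(Cc3ccccc3)[nH]2)cc1` carries the change (phenyl in place of tert-butyl on a saturated chain carbon bound to an aromatic carbon). Within the data shown here, no measured pair shows this exchange, or any change at this place, so the expectation rests only on the lack of precedent and on the wide spread between compound 2 and the other two. With nothing to suggest either direction, the expected step is a 2.4-fold higher number from compound 2 to compound 4 (0.37 log units; beyond the scatter), taken as a modest move with broad uncertainty. Compound 4 is therefore estimated at 250 nM, with a range from 60 nM to 1000 nM.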

Compound 4, half-maximal effective concentration: 205 nM
Estimate against measurement, compound 4: 1.2-fold (0.09 log units) above; the measured number falls inside the stated range.
By their numbers in this assay, from the lowest: compounds 2 and 4 (each within the scatter of the next); then compounds 3 and 1 (each within the scatter of the next).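

In this assay, for the compounds shown here, the exchange at this place gives a 1.9-fold higher number from compound 2 to compound 4 (0.29 log units; within the scatter) and so provides the first reading of any change here: phenyl in place of tert-butyl on a saturated chain carbon bound to an aromatic carbon leaves the number within the scatter. A group with one six-membered aromatic ring and a group with no ring are therefore interchangeable at this place in this one pair, and compound 2 and compound 4 cannot be ranked against each other. Nothing available bears on why the two groups read alike.

The compounds shown leave open whether this holds for a phenyl carrying a methoxy group or for an amine at the same place. They also leave open how far a longer chain between the aromatic carbon and the phenyl would move the number.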